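Shortening the alkyl chain: from compound 3 to compound 4

This account rests on a few compounds, and the source may have more. Where it says the series, first, only, none or still open, it means among the compounds named here.

Compound 1 `CCCCCCCCc1cn([C@H]2C[C@@H]3OP(=O)(O)OC[C@H]3O2)c(=O)[nH]c1=O` carries an octyl chain on the shared core; in a functional assay on Raji cells (Homo sapiens) (on this read-out lower numbers stand for stronger inhibition and higher numbers for weaker inhibition), compound 1 gives 184 ug/mL. Compound 2 `CCCc1cn([C@H]2C[C@@H]3OP(=O)(O)OC[C@H]3O2)c(=O)[nH]c1=O` bears a propyl chain on the same core. In this assay compound 2 reaches only > 500 ug/mL, which is a limit of the assay and not a number. Compound 3 `CCCCCc1cn([C@H]2C[C@@H]3OP(=O)(O)OC[C@H]3O2)c(=O)[nH]c1=O` carries a pentyl chain. In this assay compound 3 likewise stops at > 500 ug/mL, again a limit rather than a number. Compound 3 therefore stands at the limit of > 500 ug/mL in this assay, at which 2 of the 3 values shown sit, with nothing to separate it from compound 2 there.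

Compound 4 `CCCCc1cn([C@H]2C[C@@H]3OP(=O)(O)OC[C@H]3O2)c(=O)[nH]c1=O` differs from compound 3 by hydrogen in place of methyl on a saturated chain carbon, four bonds along the chain from an aromatic carbon. Within the data shown here, two measured steps bear on this shortening of the chain: an at least 2.7-fold higher number from compound 1 to compound 3 (0.43 log units; beyond the scatter) and an at least 2.7-fold higher number from compound 1 to compound 2 (0.43 log units; beyond the scatter) both run from a readable number up to the limit, while a step that the two limits leave unreadable from compound 2 to compound 3. Compound 4 sits, by chain length, between compound 2 and compound 3, both of which rest at the limit, so no change in this assay beyond the scatter is expected, and the most probable outcome is another limit. For compound 4 a value of 800 ug/mL is estimated, in the range 400 ug/mL to 2000 ug/mL. The step that the limit leaves unreadable from compound 3 to compound 4 that this estimate implies is expected to stay within the scatter.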

Compound 4, concentration for 50% inhibition: 165 ug/mL
For compound 4 the middle estimate is 4.8-fold (0.69 log units) above the measured one; measured number below the stated range.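

Hydrogen in place of methyl on a saturated chain carbon, four bonds along the chain from an aromatic carbon, gives an at least 3.0-fold lower number from compound 3 to compound 4 (0.48 log units; beyond the scatter) in this assay, and methyl in place of hydrogen on the propyl chain gives an at least 3.0-fold lower number from compound 2 to compound 4 (0.48 log units; beyond the scatter), so the butyl chain of compound 4 separates from both the pentyl and the propyl chain. Against the octyl chain there is a 1.1-fold lower number from compound 1 to compound 4 (0.05 log units; within the scatter), which leaves the butyl and octyl chains indistinguishable on this read-out, and compound 3 goes against any steady rise or fall with chain length. The step from compound 2 to compound 3 cannot be read, as each of these two compounds rests at a limit and not at a number: the limit of > 500 ug/mL in this assay, at which 2 of the 4 values shown sit.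

Still open, as far as these compounds go, is whether a chain longer than octyl, such as decyl or dodecyl, departs from the number of compound 1. Also open, from the compounds shown here alone, is how this position responds to a butyl chain ending in an amine or a carboxylic acid, or to a branched chain such as isobutyl.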